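The source may hold more compounds than are shown below. What is called first, only, known or untested is meant among the compounds shown, and "the series" means these compounds.

Measured so far in a functional assay on CHO-K1 cells for agonist activity at Glucose-dependent insulinotropic receptor (Homo sapiens), read by a luciferase reporter, with a stated time of 5 h; on this read-out higher numbers stand for an effect only at larger amounts of compound and lower numbers for an effect already at smaller amounts:
compound 1, `CC(=O)N1CCN(c2ccc(OCC3CCN(C(=O)OC(C)C)CC3)cn2)CC1`, gives only a limit of the assay, > 10000 nM.
compound 2, `CC(C)OC(=O)N1CCC(COc2ccc(N3CCN(S(=O)(=O)CC4CCCCC4)CC3)nc2)CC1`, gives 90 nM.

Going by the values given here, compound 2 stands as the only number among the values in this assay; the other value is a limit, (the limit of > 10000 nM in this assay, at which 1 of the 2 values shown sits). Among the compounds with values here, the single measured step, an at least 110-fold lower number from compound 1 to compound 2 (2.04 log units; beyond the scatter), is large and concerns the group on the ring amine nitrogen, acetyl giving way to (cyclohexylmethyl)sulfonyl.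

Compound 3, `CCN(CC)S(=O)(=O)N1CCN(c2ccc(OCC3CCN(C(=O)OC(C)C)CC3)cn2)CC1`, keeps the sulfonyl and the core of compound 2 and changes what sits on the sulfonyl sulfur: diethylamino in place of cyclohexylmethyl on a sulfonyl sulfur. Within the data shown here, no measured step bears directly on this exchange; the step from compound 1 to compound 2 shows only that removing acetyl in favour of the larger sulfonyl group moves the number a long way, and it does not separate the part the sulfonyl plays from the part the cyclohexylmethyl plays. With the ring gone and a smaller group in its place, some loss is expected, but of uncertain size. Compound 3 is expected to give about 500 nM in this assay, with a range from 100 nM to 3000 nM. The step expected for compound 3 is a 5.6-fold higher number from compound 2 to compound 3 (0.74 log units; beyond the scatter).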

Compound 3, half-maximal effective concentration: 1200 nM
Beside the measured number, compound 3's estimate is 2.4-fold (0.38 log units) below it; the measured number falls inside the stated range.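

With the sulfonyl kept in this assay, the group on the sulfonyl sulfur carries weight of its own, since diethylamino in place of cyclohexylmethyl gives a 13-fold higher number from compound 2 to compound 3 (1.12 log units; beyond the scatter). The carbocyclic ring is still not a requirement for a measurable number at this position, as diethylsulfamoyl in place of acetyl on the ring amine nitrogen gives an at least 8.3-fold lower number from compound 1 to compound 3 (0.92 log units; beyond the scatter). The value of compound 1 is a limit and not a number, so this second step is a bound only: the limit of > 10000 nM in this assay, at which 1 of the 3 values shown sits.

The exchange from compound 2 to compound 3 alters the ring and the atom attached to the sulfonyl sulfur at once, so a piperidine bound through its nitrogen or an open-chain hexyl group on the sulfur would be needed to tell these two changes apart. The contribution of the sulfonyl itself also remains unseparated from that of the group it carries, and a cyclohexylacetyl group on the ring amine nitrogen would divide the two.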